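Urea series, compound 4: one ring nitrogen moved

The source may hold more compounds than are shown below. What is called first, only, known or untested is meant among the compounds shown, and "the series" means these compounds.

Measured so far:
- compound 1 `O=C(Nc1ccc(-n2ncc3c(F)cccc32)cc1)Nc1ccc(Cl)c(C(F)(F)F)c1`: 8200 nM
- compound 2 `O=C(Nc1ccc(-n2ncc3ccccc32)cc1)Nc1ccc(Cl)c(C(F)(F)F)c1`: 18200 nM
- compound 3 `O=C(Nc1ccc(-n2ncc3ccncc32)cc1)Nc1ccc(Cl)c(C(F)(F)F)c1`: 29500 nM

In a functional assay on HT-29 cells (Homo sapiens) for cytotoxicity, read by MTT assay, with a stated time of 72 h (a higher number here means a weaker inhibitor, a lower number a stronger inhibitor), compound 3 carries the highest number of the three; the step of a 1.6-fold higher number from compound 2 to compound 3 (0.21 log units; within the scatter) is within the scatter, whereas a 3.6-fold higher number from compound 1 to compound 3 (0.56 log units; beyond the scatter) lies beyond it. Compound 4 `O=C(Nc1ccc(-n2ncc3cccnc32)cc1)Nc1ccc(Cl)c(C(F)(F)F)c1` has the same atoms as compound 3, joined differently: a group of 9 heavy atoms (6 carbon, 3 nitrogen; one five-membered aromatic ring with 2 hetero atoms, one six-membered aromatic ring with 1 hetero atom) in place of a group of 9 heavy atoms (6 carbon, 3 nitrogen; one five-membered aromatic ring with 2 hetero atoms, one six-membered aromatic ring with 1 hetero atom), on an aromatic carbon, on an aromatic carbon of a six-membered aromatic ring of carbon only, para to a large group. Within the data shown here, no measured step compares two such arrangements of the same atoms. The steps of a 1.6-fold higher number from compound 2 to compound 3 (0.21 log units; within the scatter) and a 2.2-fold higher number from compound 1 to compound 2 (0.35 log units; beyond the scatter) concern adding a ring nitrogen or removing fluoro, not relocating a nitrogen, so they bear only indirectly. A step of no more than the scatter is therefore expected, with a 1.2-fold lower number from compound 3 to compound 4 (0.07 log units; within the scatter) as the working figure. Compound 4 is estimated at 25000 nM, range 10000 nM to 65000 nM.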

Compound 4, half-maximal inhibitory concentration: > 32000 nM
Compound 4 was reported as a limit (the forecaster's own chance of this, stated with the estimate: 10%); middle value at least 1.2-fold (0.10 log units) from the limit.
By their numbers in this assay, from the lowest: compound 1; then compounds 2 and 3 (each within the scatter of the next). At a limit, above all of these: compound 4.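

In this assay compound 4 gives > 32000 nM, which is a limit and not a number. Relocating the ring nitrogen gives an at least 1.0-fold higher number from compound 3 to compound 4 (0.03 log units; that floor lies within the scatter), and the other nitrogen-bearing comparison gives an at least 1.7-fold higher number from compound 2 to compound 4 (0.24 log units; that floor lies within the scatter), so neither floor separates the two compounds of its pair. Only an at least 3.9-fold higher number from compound 1 to compound 4 (0.59 log units; beyond the scatter) clears the scatter, so this placement of the nitrogen, like that in compound 3, does not match the fluoro compound.

Going by these compounds, the true value of compound 4 remains open. Also open, on these data alone, is whether an amine or a chloro group in place of the fluoro of compound 1 would hold its number.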